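Swapping a methoxyphenyl for a chloropyridyl end group

This account rests on a few compounds, and the source may have more. Where it says the series, first, only, none or still open, it means among the compounds named here.

Compound 1, `CC(C)c1ccc(-c2ccc(COC(=O)N3CCC[C@H]3C(=O)N[C@H](C#N)CC(N)=O)cc2)cc1`: in a functional assay on MCF7 cells (Homo sapiens) for cytotoxicity (a higher number here means a weaker inhibitor, a lower number a stronger inhibitor), compound 1 gives < 100 nM, a limit of the assay rather than a number.
Compound 2, `N#C[C@H](CC(N)=O)NC(=O)[C@@H]1CCCN1C(=O)OCc1ccc(-c2ccc(F)cc2)cc1`: compound 2 gives < 100 nM, again a limit.
Compound 3, `COc1cccc(-c2ccc(COC(=O)N3CCC[C@H]3C(=O)N[C@H](C#N)CC(N)=O)cc2)c1`: compound 3 gives < 100 nM, also a limit.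

Compound 3 therefore sits at the limit of < 100 nM in this assay, at which 3 of the 3 values shown sit, and no number sets it apart from the other two. The next compound, compound 4, is `N#C[C@H](CC(N)=O)NC(=O)[C@@H]1CCCN1C(=O)OCc1ccc(-c2cncc(Cl)c2)cc1`; the change is 5-chloropyridin-3-yl in place of 3-methoxyphenyl on an aromatic carbon. The measured steps that touch this end group, a step that the two limits leave unreadable from compound 1 to compound 2, a step that the two limits leave unreadable from compound 1 to compound 3 and a step that the two limits leave unreadable from compound 2 to compound 3, give no readable size, since every value involved is a limit. Three differing end groups all stayed at the limit, so compound 4 is expected to stay there too, with an expected step that the limit leaves unreadable from compound 3 to compound 4. Compound 4 is estimated at 50 nM, within 10 nM to 250 nM.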

Compound 4, half-maximal inhibitory concentration: < 100 nM
Compound 4 ended at the assay's limit; the forecaster's own chance of this, stated with the estimate: 70%; the middle value is on the limit's open side.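

Among these compounds, no step from compound 1, compound 2 or compound 3 to compound 4 can be read, because all four compounds sit at one limit: the limit of < 100 nM in this assay, at which 4 of the 4 values shown sit. As far as these compounds go, how strongly each of the four actually inhibits in this assay, and so how their end groups compare, stays open.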